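A Bulkier Ester in Place of the Acetoxy Group

This account rests on a few compounds, and the source may have more. Where it says the series, first, only, none or still open, it means among the compounds named here.

Measured compounds:
Compound 1 `CC(C(=O)NCc1ccc(C(F)(F)F)nc1N1CCC(Cc2ccc(F)c(F)c2)CC1)c1ccc(NS(C)(=O)=O)c(F)c1` — 0.2 nM
Compound 2 `CC(=O)OC1CCN(c2nc(C(F)(F)F)ccc2CNC(=O)C(C)c2ccc(NS(C)(=O)=O)c(F)c2)CC1` — 4 nM

Of the compounds shown here, two have been tested in a functional assay on CHO-K1 cells for antagonist activity at transient receptor potential cation channel subfamily V member 1 (Homo sapiens), read by FLIPR; a higher number here means a weaker inhibitor, a lower number a stronger inhibitor. Compound 1 gives 0.2 nM in this assay, and compound 2 gives 4 nM. Between them lies a single structural change, acetoxy in place of 3,4-difluorobenzyl on a saturated ring carbon, and it costs a 20-fold higher number from compound 1 to compound 2 (1.30 log units; beyond the scatter). Compound 2 therefore stands with the higher of the two numbers, the weaker inhibitor of the pair.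

Compound 3 `CC(C(=O)NCc1ccc(C(F)(F)F)nc1N1CCC(OC(=O)C(C)(C)C)CC1)c1ccc(NS(C)(=O)=O)c(F)c1` has not been measured. It differs from compound 2 by tert-butyl in place of methyl on a carbonyl carbon: the acetyl of the ester becomes a (tert-butyl)carbonyl, so the acetoxy becomes a ((tert-butyl)carbonyl)oxy. For the measured compounds named here, no measured step touches this carbonyl carbon; the only step seen concerns a different exchange at the saturated ring carbon, so nothing measured bears directly on enlarging the ester. With no guide from the data, the expectation for compound 3 in this assay is a step of a 1.3-fold lower number from compound 2 to compound 3 (0.12 log units; within the scatter), within the scatter. Compound 3 is thus estimated at 3 nM, with a plausible range from 0.8 nM to 15 nM.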

Compound 3, inhibition constant: 2 nM
For compound 3 the middle estimate is 1.5-fold (0.18 log units) above the measured one; measured number inside the range.
By their numbers in this assay, from the lowest: compound 1; then compounds 3 and 2 (each within the scatter of the next).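

Enlarging the ester by putting tert-butyl in place of methyl on the carbonyl carbon gives a 2.0-fold lower number from compound 2 to compound 3 (0.30 log units; within the scatter) in this assay and so, on this evidence, the two esters cannot be told apart, even though tert-butyl carries more carbons than methyl. The ester with the larger group also does not match the 3,4-difluorobenzyl group on the saturated ring carbon, since exchanging that group for ((tert-butyl)carbonyl)oxy gives a 10-fold higher number from compound 1 to compound 3 (1.00 log units; beyond the scatter) and leaves compound 1 clearly the stronger inhibitor of that pair. Nothing available here explains why either change has the size it does.

The compounds shown leave open whether other groups on this carbonyl carbon, such as a longer straight chain like n-butyl or a phenyl ring, would also stay within the scatter of the acetoxy compound, or would instead move the number towards that of compound 1. They also leave open whether the ester link itself matters, which a simple hydroxyl group or an amine on the saturated ring carbon could begin to answer.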